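Swapping the Heteroaryl Ring on the Shared Core

The compounds below may be only part of what the source reports. "The series", "measured", "known", "first", "only" and "open" are said of these compounds alone.

Measured compounds:
compound 1, `COc1cc(CSc2cc(Cl)c(-c3nnc(-c4ccc(Cl)cc4)s3)cc2S(=O)(=O)NC(=N)NO)cc(OC)c1OC`, 26300 nM
compound 2, `N=C(NO)NS(=O)(=O)c1cc(-c2nnc(-c3ccc(Cl)cc3)s2)c(Cl)cc1SCc1ccccc1`, 2100 nM

In a functional assay on UACC-257 cells (Homo sapiens) (a lower number here means a stronger inhibitor of growth, a higher number a weaker inhibitor of growth), compound 1 gives 26300 nM, the highest of the two numbers. Going by the values given here, its only neighbour is compound 2, and the single measured step, a 13-fold lower number from compound 1 to compound 2 (1.10 log units; beyond the scatter), comes from putting phenyl in place of 3,4,5-trimethoxyphenyl on a saturated chain carbon bound to a sulfur.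

Compound 3, `COc1cc(CSc2cc(Cl)c(-c3nc(-c4ccccc4)no3)cc2S(=O)(=O)NC(=N)NO)cc(OC)c1OC`, has not been measured. It differs from compound 1 by 3-phenyl-1,2,4-oxadiazol-5-yl in place of 5-(4-chlorophenyl)-1,3,4-thiadiazol-2-yl on an aromatic carbon. Among the compounds with values here, the step from compound 1 to compound 2 alters a different part of the molecule and therefore says nothing about this ring exchange; no measured step bears on it. Without such a guide, the expectation for compound 3 in this assay is a number close to that of compound 1, with no step beyond the scatter, but with wide uncertainty. Compound 3 is therefore estimated at 25000 nM, within a range from 6000 nM to 90000 nM, which would mean an expected step of a 1.1-fold lower number from compound 1 to compound 3 (0.02 log units; within the scatter).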

Compound 3, concentration for 50% growth inhibition: 13200 nM
Compound 3: middle estimate off by 1.9-fold (0.28 log units), on the high side; low and high end bracket the measured number.
By their numbers in this assay, from the lowest: compound 2; then compounds 3 and 1 (each within the scatter of the next).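

In this assay, exchanging the whole group on this aromatic carbon gives a 2.0-fold lower number from compound 1 to compound 3 (0.30 log units; within the scatter). The numbers for the two compounds therefore cannot be told apart, so at this position of the core of compound 1, 3-phenyl-1,2,4-oxadiazol-5-yl can stand in for 5-(4-chlorophenyl)-1,3,4-thiadiazol-2-yl, even though the five-membered ring and the chlorine on the outer phenyl ring are exchanged together. No measurement available here accounts for this result.

From the compounds shown here alone, what stays open is how much the five-membered ring and the chlorine each contribute, since a single step cannot separate them; a 3-(4-chlorophenyl)-1,2,4-oxadiazol-5-yl group would divide the exchange in two. Also open, going by these compounds, is how a very different group at this carbon, such as a carboxylic acid or an amine, would behave in this assay.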